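The compounds below may be only part of what the source reports. "The series", "measured", "known", "first", "only" and "open" are said of these compounds alone.

In an assay on isolated protein for inhibition of AP2-associated protein kinase 1 (Homo sapiens), with a stated time of 3 h, in the presence of a further agent that is not named here (a higher number here means a weaker inhibitor, a lower number a stronger inhibitor), three compounds have been measured. Compound 1 `COC(=O)Nc1cc(-c2cnc(OC[C@@](C)(N)CC(C)C)c(OC)c2)ccn1` gives 3.8 nM, compound 2 `COC(=O)Nc1cc(-c2cnc(OC[C@@](C)(N)CC(C)C)c(Cl)c2)ccn1` gives 0.4 nM, and compound 3 `CC(C)C[C@](C)(N)COc1cnc(-c2ccnc(Cl)c2)cc1C(F)F` gives 0.8 nM. Compound 2 therefore holds the lowest of the three numbers; its gap to compound 3 lies within the scatter, whereas the step of a 9.5-fold lower number from compound 1 to compound 2 (0.98 log units; beyond the scatter) lies beyond it. Compound 4 `COC(=O)Nc1cc(-c2cnc(OC[C@@](C)(N)CC(C)C)c(C#N)c2)ccn1` differs from compound 2 by cyano in place of chloro on an aromatic carbon. Among the compounds with values here, the single measured step touching this aromatic carbon was modest in size, and no measured pair exchanges chloro for cyano, so the change for compound 4 is expected to be small, with the step of a 1.8-fold higher number from compound 2 to compound 4 (0.24 log units; within the scatter) expected to stay within the scatter. Compound 4 is accordingly estimated at 0.7 nM, within a range from 0.25 nM to 2.5 nM.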

Compound 4, half-maximal inhibitory concentration: 1 nM
Beside the measured number, compound 4's estimate is 1.4-fold (0.15 log units) below it, and the stated range covers the measured number.
By their numbers in this assay, from the lowest: compounds 2, 3 and 4 (each within the scatter of the next, the first and the last beyond it); then compound 1.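

In this assay, this aromatic carbon, ortho to the (2-amino-2,4-dimethylpentyl)oxy group, now has a third group to compare: cyano in place of chloro gives a 2.5-fold higher number from compound 2 to compound 4 (0.40 log units; beyond the scatter) and cyano in place of methoxy gives a 3.8-fold lower number from compound 1 to compound 4 (0.58 log units; beyond the scatter). Both steps lie beyond the scatter, so among these three groups the number rises from chloro to cyano to methoxy. Nothing available explains this order. The compounds shown leave open how a fluoro, methyl or amine group would read at this carbon.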